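The compounds below may be only part of what the source reports. "The series", "measured", "known", "first", "only" and "open" are said of these compounds alone.

Of the compounds shown here, three have so far been measured in a physicochemical assay for lipophilicity; on this read-out higher numbers stand for higher lipophilicity and lower numbers for lower lipophilicity. Compound 1 `COc1ccc(C2=NO[C@]3(C2)C(=O)O[C@@H]2[C@H]3CC[C@H](C)[C@]3(O)C=CC(=O)[C@@]23C)cc1` gives 1.47. Compound 2 `C[C@H]1CC[C@@H]2[C@@H](OC(=O)[C@]23CC(c2ccccc2)=NO3)[C@]2(C)C(=O)C=C[C@@]12O` gives 1.41. Compound 3 `Cc1ccc(C2C[C@@]3(ON2c2ccccc2)C(=O)O[C@@H]2[C@H]3CC[C@H](C)[C@]3(O)C=CC(=O)[C@@]23C)cc1` gives 3.64, the highest of the three numbers; its gap to compound 1 and its gap to compound 2 both lie beyond the scatter, so compound 3 is the most lipophilic of the measured set.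

For the measured compounds named here, only one measured step joins two compounds that differ in a single place: a number 0.06 log units lower from compound 1 to compound 2 (within the scatter). Going by the values given here, this step concerns a different group on a different part of the shared core, so no measured step directly covers the change now under consideration.

Compound 4 `C[C@H]1CC[C@@H]2[C@@H](OC(=O)[C@]23CC(c2ccccc2F)N(c2ccccc2)O3)[C@]2(C)C(=O)C=C[C@@]12O` has not yet been measured. It differs from compound 3 in one place: 2-fluorophenyl in place of 4-methylphenyl on a saturated ring carbon. Both the leaving and the entering group are six-membered aromatic rings of the same heavy-atom count, without donors or acceptors. Among the compounds with values here, with no matching measured step, the expectation rests on the small size of the only known swap on an aromatic ring, which stayed within the scatter. The step from compound 3 to compound 4 is therefore expected to be small, at most slightly downward: a number 0.29 log units lower from compound 3 to compound 4 (within the scatter). For compound 4 the expected value is 3.35, within a range from 2.85 to 3.85.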

Compound 4, partition coefficient: 3.35
The estimate for compound 4 equals the measured number at the digits printed; measured number inside the range.
By their numbers in this assay, from the lowest: compounds 2 and 1 (each within the scatter of the next); then compounds 4 and 3 (each within the scatter of the next).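

In this assay, for the compounds shown here, replacing 4-methylphenyl with 2-fluorophenyl on the saturated ring carbon next to the ring nitrogen gives a number 0.29 log units lower from compound 3 to compound 4 (within the scatter) and so provides the first measured step at this position, since the earlier step of a number 0.06 log units lower from compound 1 to compound 2 (within the scatter) concerned a group on an aromatic carbon elsewhere on the shared core. The swap keeps the heavy-atom count, the single six-membered aromatic ring and the absence of hydrogen-bond donors and acceptors, so across this pair the read-out stays within the scatter when a methyl group is lost and a fluorine gained at a different ring position. No measurement at hand explains this result or separates the part played by the methyl group from that of the fluorine.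

Without the plain phenyl group at this carbon, neither the methyl group nor the fluorine can be judged on its own. From the compounds shown here alone, it also remains open how far the read-out would move if a group unlike these aromatic rings, such as a primary amine, a carboxylic acid or a longer alkyl chain, stood at this carbon.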